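Aryl ketone variation on the shared core

This account rests on a few compounds, and the source may have more. Where it says the series, first, only, none or still open, it means among the compounds named here.

The series shares the core of compound 1 `N#C/C(=C\c1c(-c2ccccc2)[nH]c2ccccc12)C(=O)c1cccs1` and varies the groups on the carbonyl carbons attached to the double-bonded chain carbon. In a functional assay on CCRF-CEM cells (Homo sapiens) for cytotoxicity, read by MTT assay, with a stated time of 96 h (on this read-out lower numbers stand for an effect already at smaller amounts and higher numbers for an effect only at larger amounts of compound), compound 1 gives 1200 nM. Compound 2 `O=C(/C(=C\c1c(-c2ccccc2)[nH]c2ccccc12)C(=O)C(F)(F)F)c1ccco1` gives 1900 nM in this assay, a gap to compound 1 that lies within the scatter, so the two cannot be separated. Compound 3 `O=C(C(=Cc1c(-c2ccccc2)[nH]c2ccccc12)C(=O)c1ccccc1)c1ccccc1` gives 12000 nM, a gap to compound 1 that is beyond the scatter; compound 3 differs from compound 1 in more than one place, so only the two values themselves are informative. Compound 1 therefore sits at the low end of the three numbers, with compound 2 alongside it and compound 3 clearly apart.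

Compound 4 `N#C/C(=C\c1c(-c2ccccc2)[nH]c2ccccc12)C(=O)c1ccc(Cl)cc1` is not yet measured. Its difference from compound 1 is 4-chlorophenyl in place of thiophen-2-yl on a carbonyl carbon. Going by the values given here, no measured pair covers this exchange alone, so no step size is known for it. The expectation is a step that stays within or close to the scatter, if anything toward a somewhat higher number. For compound 4 the estimated value in this assay is 2000 nM, with a range from 700 nM to 6000 nM. The expected step is a 1.7-fold higher number from compound 1 to compound 4 (0.22 log units; within the scatter).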

Compound 4, half-maximal effective concentration: 1100 nM
The estimate for compound 4 lay 1.8-fold (0.26 log units) above the measured number; low and high end bracket the measured number.
By their numbers in this assay, from the lowest: compounds 4, 1 and 2 (each within the scatter of the next); then compound 3.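

Going by these compounds alone, with the nitrile kept on the double-bonded chain carbon, the exchange of thiophen-2-yl for 4-chlorophenyl on a carbonyl carbon gives the first readable step: in this assay it is a 1.1-fold lower number from compound 1 to compound 4 (0.04 log units; within the scatter) and so cannot be told apart from repeat measurement. For this one pair, a six-membered aromatic ring of carbon only, bearing chlorine, thus reads the same as a five-membered aromatic ring with a sulfur atom, even though the hydrogen-bond acceptor counted for thiophen-2-yl is absent from 4-chlorophenyl. Nothing measured here accounts for why the two groups read alike.

As far as these compounds go, whether the chlorine contributes anything apart from the ring remains open, and unsubstituted phenyl, 4-methoxyphenyl or an aryl group carrying an amine on this carbonyl carbon would test how far the tolerance extends. The high number of compound 3 also stays unassigned, since compound 3 differs from compound 1 in more than one place, and the separate contributions of the nitrile and the second carbonyl group cannot be read from the compounds shown.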